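Series notes: trifluoromethyl in place of methyl

The compounds below may be only part of what the source reports. "The series", "measured", "known", "first", "only" and "open" are said of these compounds alone.

Measured compounds:
Compound 1 `COc1cc2c(Oc3ccc(NC(=O)c4nn(-c5ccccc5)c(=O)cc4C)cc3F)ccnc2cc1OCCCN1CCCCC1` gives 160 nM in a functional assay on MKN-45 cells (Homo sapiens) for inhibition, read by MTT assay, with a stated time of 72 h; a lower number here means a stronger inhibitor, a higher number a weaker inhibitor.
Compound 2 `COc1cc2c(Oc3ccc(NC(=O)c4nn(-c5ccccc5C)c(=O)cc4C)cc3F)ccnc2cc1OCCCN1CCCCC1` gives 1310 nM in this assay.
Compound 3 `COc1cc2c(Oc3ccc(NC(=O)c4nn(-c5ccccc5C)c(=O)cc4C)cc3F)ccnc2cc1OCCCN1CCC(C)CC1` gives 1290 nM in this assay.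

Compound 2 has the highest number of the three; compound 3 lies within the scatter of it, while compound 1 is well below it. The step of an 8.2-fold higher number from compound 1 to compound 2 (0.91 log units; beyond the scatter) is beyond the scatter; the step of a 1.0-fold lower number from compound 2 to compound 3 (0.01 log units; within the scatter) is not.

Compound 4 `COc1cc2c(Oc3ccc(NC(=O)c4nn(-c5ccccc5C(F)(F)F)c(=O)cc4C)cc3F)ccnc2cc1OCCCN1CCCCC1` differs from compound 2 by trifluoromethyl in place of methyl on an aromatic carbon. Going by the values given here, no measured step exchanges methyl for trifluoromethyl; the only step at this aromatic carbon, an 8.2-fold higher number from compound 1 to compound 2 (0.91 log units; beyond the scatter), shows that a group there matters. For compound 4 a number near or somewhat above that of compound 2 is expected, a 1.4-fold higher number from compound 2 to compound 4 (0.14 log units; within the scatter). The estimate for compound 4 is 1800 nM, range 600 nM to 6000 nM.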

Compound 4, half-maximal inhibitory concentration: 90 nM
Compound 4: middle estimate off by 20-fold (1.30 log units), on the high side; measured number below the stated range.
By their numbers in this assay, from the lowest: compounds 4 and 1 (each within the scatter of the next); then compounds 3 and 2 (each within the scatter of the next).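

At this aromatic carbon the outcome depends on which group sits there, not merely on a group being present: in this assay trifluoromethyl in place of methyl gives a 15-fold lower number from compound 2 to compound 4 (1.16 log units; beyond the scatter) and so reverses the loss seen with methyl. Against hydrogen, trifluoromethyl gives a 1.8-fold lower number from compound 1 to compound 4 (0.25 log units; within the scatter) and stays within the scatter. Nothing at hand bears on why these two groups part so widely.

On these data alone, whether chlorine, methoxy or nitrile at this carbon would track methyl or trifluoromethyl remains open. Also open, as far as these compounds go, is whether the methyl on the saturated ring carbon stays without effect alongside trifluoromethyl.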